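A few compounds are considered here, and "the series" means these few. Any claim that something is new, unique, unknown or untested is made for them only; others in the source may bear on it.

Measured compounds in a functional assay on the whole organism with Mus musculus as the target, in the maximal electroshock model; on this read-out higher numbers stand for an effect only at larger amounts of compound and lower numbers for an effect already at smaller amounts:
compound 1 `O=C1CCC2(c3ccc(Cl)cc3)OCCCN12` gives 58 mg/kg
compound 2 `O=C(CCC(=O)c1ccc(Cl)c(Cl)c1)NCCCO` gives 450 mg/kg
compound 3 `O=C1CCC2(c3ccc(Cl)c(Cl)c3)OCCCN12` gives 113 mg/kg

Compound 1 and compound 3 share the same ring-closed core and differ at one place only.

hydrogen in place of chloro on an aromatic carbon

In this assay this gives a 1.9-fold lower number from compound 3 to compound 1 (0.29 log units; within the scatter). Compound 2 has an open-chain core; the difference between the two cores is not broken down here. Among the three numbers, compound 2 stands highest: compound 3 is the nearest, compound 1 the furthest, and both gaps are beyond the scatter.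

Compound 4 `O=C(CCC(=O)c1ccc(Cl)cc1)NCCCO` is not yet measured and differs from compound 2 at one place.

hydrogen in place of chloro on an aromatic carbon

The place is described in the same words as for the pair compound 3 to compound 1, so this is the same change, and it occurs twice among the compounds here. For the measured compounds named here, it has been seen only once with a number attached, and only on the ring-closed core; for the open-chain core no second pair exists, so any expectation rests on that single pair. The step from compound 2 to compound 4 is therefore expected to be a 1.8-fold lower number from compound 2 to compound 4 (0.26 log units; within the scatter), a step of the same kind and size as seen from compound 3 to compound 1, because that pair gave a 1.9-fold lower number from compound 3 to compound 1 (0.29 log units; within the scatter).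

Compound 4 is estimated at 250 mg/kg in this assay, with a range from 120 mg/kg to 520 mg/kg.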

Compound 4, dose for half-maximal effect: > 300 mg/kg
Compound 4: only a limit was reported; the forecaster's own chance of this, stated with the estimate: 10%; middle value at least 1.2-fold (0.07 log units) away from the limit.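

In this assay compound 4 gives > 300 mg/kg as a limit and not as a number. The step between compound 2 and compound 4 cannot be read in size because of this limit: the limit of > 300 mg/kg in this assay, at which 1 of the 4 values shown sits. Still open, from the compounds shown here alone, is whether hydrogen in place of chloro on an aromatic carbon acts on the open-chain core as in the only readable case, a 1.9-fold lower number from compound 3 to compound 1 (0.29 log units; within the scatter) on the ring-closed core.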